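A few compounds are considered here, and "the series" means these few. Any claim that something is new, unique, unknown or untested is made for them only; others in the source may bear on it.

Measured so far:
- compound 1, `CC(=O)Nc1nc(-c2cccc(NS(=O)(=O)c3cccc(Br)c3)c2)cs1`: "not active" (no number reported)
- compound 2, `CC(=O)Nc1nc(-c2cccc(NS(=O)(=O)c3ccc(C#CCO)cc3)c2)cs1`: 81.3%
- compound 3, `CCCCCCC#Cc1cccc(S(=O)(=O)Nc2cccc(-c3csc(NC(C)=O)n3)c2)c1`: 56.9%

In a functional assay on A-375 cells (Homo sapiens) for antiproliferative activity, read by trypan blue exclusion, with a stated time of 48 h, tested at 1 uM (on this read-out lower numbers stand for a stronger effect and higher numbers for a weaker effect at the one concentration tested), compound 1 is reported as "not active" (no number reported) without a number, and that entry is taken only as such. Among the two numbers, compound 2 has the highest value, 81.3%, which on this read-out is the weaker effect; compound 3 stands at 56.9%, a gap that lies beyond the usual scatter. For the measured compounds named here, no two of the measured compounds differ in one place only, so no single step has been measured.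

Compound 4, `CCCCCCc1ccc(S(=O)(=O)Nc2cccc(-c3csc(NC(C)=O)n3)c2)cc1`, is not yet measured. It differs from compound 2 as follows: hexyl in place of 3-hydroxyprop-1-yn-1-yl on an aromatic carbon. The change exchanges a short chain that carries a hydroxyl and a triple bond for a plain hexyl chain at the same place on the ring, para to a large group.

For compound 4 a moderate step downward from compound 2 is expected in this assay, beyond the scatter but without a measured step to anchor it; the value of compound 3, 56.9%, with its longer hydrocarbon chain, is the only hint that a long chain goes with a lower number. The expected step is a number 16.3 percentage points lower from compound 2 to compound 4 (beyond the scatter). Compound 4 is thus estimated at 65%, within 40% to 90%.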

Compound 4, a percentage reported as activity, at one concentration (the size of the read-out at that concentration, not a potency): 49.9%
Compound 4: middle estimate off by 15.1 percentage points, on the high side, within the range that was stated.
By their numbers in this assay, from the lowest: compounds 4 and 3 (each within the scatter of the next); then compound 2.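

In this assay, for the compounds shown here, the exchange at this aromatic carbon, para to a large group, provides the first single-place step: a number 31.4 percentage points lower from compound 2 to compound 4 (beyond the scatter), with hexyl in place of 3-hydroxyprop-1-yn-1-yl. The read-out at this position therefore responds to the group placed there, and of the two groups compared, hexyl goes with the stronger effect at the one concentration tested. The exchange alters the chain length and removes both the triple bond and the hydroxyl in one step, so the step cannot be assigned to any one of these, and no available evidence bears on its cause.

As far as these compounds go, it remains open which of these differences carries the step; a 3-hydroxypropyl or a prop-1-yn-1-yl group at the same place would separate the hydroxyl from the triple bond. Also open, from the compounds shown here alone, is how the read-out at this place would respond to a longer chain such as octyl, or to a hexyl chain ending in an amine or a carboxylic acid.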